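Extending a Carbon Chain in Two Different Places

This account rests on a few compounds, and the source may have more. Where it says the series, first, only, none or still open, it means among the compounds named here.

Compound 1 `Cc1ccc(C(=O)NN(C(=O)c2ccccc2Cl)C(C)(C)C)cc1`: 18.6 nM
Compound 2 `CCCc1ccc(C(=O)NN(C(=O)c2ccccc2Cl)C(C)(C)C)cc1`: 9.12 nM
Compound 3 `CCCCCCCC(=O)NN(C(=O)c1cc(C)cc(C)c1)C(C)(C)C`: 97.7 nM

All three compounds were tested in an assay on cells for agonist activity at ecdysone receptor (Bombyx mori), read by a luciferase reporter, with a stated time of 24 h; on this read-out lower numbers stand for an effect already at smaller amounts and higher numbers for an effect only at larger amounts of compound. Compound 1 gives 18.6 nM, compound 2 gives 9.12 nM, and compound 3 gives 97.7 nM. Compound 2 differs from compound 1 by ethyl in place of hydrogen on a saturated chain carbon bound to an aromatic carbon, and that change brought a 2.0-fold lower number from compound 1 to compound 2 (0.31 log units; beyond the scatter). Compound 3 has a different core from compound 1, and the difference between the two cores is not broken down here. Compound 4 `CCCCCCCCCC(=O)NN(C(=O)c1cc(C)cc(C)c1)C(C)(C)C` is not yet measured; it differs from compound 3 by ethyl in place of hydrogen on a saturated chain carbon, seven bonds along the chain from a carbonyl carbon. Going by the values given here, this is the same kind of change as the one from compound 1 to compound 2, but not the same: in compound 2 the ethyl sits on a saturated chain carbon bound to an aromatic carbon, while in compound 4 it sits on a saturated chain carbon seven bonds along the chain from a carbonyl carbon. Because the earlier step of a 2.0-fold lower number from compound 1 to compound 2 (0.31 log units; beyond the scatter) was modest and the place differs, only a small effect is expected here, with the number for compound 4 estimated at 120 nM, between 40 nM and 360 nM, which is expected to mean a 1.2-fold higher number from compound 3 to compound 4 (0.09 log units; within the scatter).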

Compound 4, half-maximal effective concentration: 1550 nM
Compound 4: middle estimate off by 13-fold (1.11 log units), on the low side; measured number above the stated range.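

In this assay the ethyl in place of hydrogen on a saturated chain carbon, seven bonds along the chain from a carbonyl carbon, brought a 16-fold higher number from compound 3 to compound 4 (1.20 log units; beyond the scatter) and so moved the number the opposite way from the earlier step on the core of compound 1. Set side by side, the two steps differ, and this kind of change did not carry over from one core to the other: the same change on two cores in this assay, a 2.0-fold lower number (0.31 log units; beyond the scatter) from compound 1 to compound 2 and a 16-fold higher number (1.20 log units; beyond the scatter) from compound 3 to compound 4, 32-fold (1.51 log units) apart, beyond the scatter of two such steps. The comparison rests on a single pair for each core, and the ethyl sits in a different place in each pair, so it does not show whether the core or the place accounts for the gap.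

As far as these compounds go, it remains open whether a longer chain on the core of compound 3 would raise the number further, and whether a longer chain on the core of compound 1 would keep lowering it or turn the same way. From the compounds shown here alone, it is also open how an amine or a carboxylic acid in place of the ethyl would behave on either core.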